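Disulfide chain length and half-life in the series

A few compounds are considered here, and "the series" means these few. Any claim that something is new, unique, unknown or untested is made for them only; others in the source may bear on it.

Compound 1 `Cc1cn([C@H]2C[C@H](SSC(Cl)(Cl)Cl)[C@@H](CO)O2)c(=O)[nH]c1=O` and compound 2 `C=CCSS[C@H]1C[C@H](n2cc(C)c(=O)[nH]c2=O)O[C@@H]1CO` share one core and differ by allyl in place of trichloromethyl on a sulfur. In a physicochemical assay for metabolic stability, in the presence of a further agent that is not named here (on this read-out lower numbers stand for a shorter-lived compound and higher numbers for a longer-lived compound), compound 1 gives only a limit, < 1.5 h. In this assay compound 2 likewise gives only a limit, < 8 h. The step that the two limits leave unreadable from compound 1 to compound 2 cannot be read, since the limit of < 1.5 h in this assay, at which 1 of the 2 values shown sits, and the limit of < 8 h in this assay, at which 1 of the 2 values shown sits, both sit at limits. Compound 3 `CCCCCCSS[C@H]1C[C@H](n2cc(C)c(=O)[nH]c2=O)O[C@@H]1CO` differs from compound 2 by pentyl in place of vinyl on a saturated chain carbon bound to a sulfur. Going by the values given here, no measured step bears on this change, so no shift beyond the scatter is expected. The expected step that the limit leaves unreadable from compound 2 to compound 3 is an estimate only. For compound 3 the estimate in this assay is 4 h, with a range from 1 h to 16 h.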

Compound 3, half-life: < 8 h
Compound 3 gave a limit, no number; the forecaster's own chance of this, stated with the estimate: 50%; the middle value is on the limit's open side.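

Compound 3, like compound 1 and compound 2, gives only a limit in this assay, so no step among these compounds can be read. On these data alone, how far hexyl, allyl and trichloromethyl on a sulfur differ in half-life stays open.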